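A Chloro Group Added to Compound 2

The source may report more compounds than this note shows. Statements on the series, on what has been measured and on what is new or still open speak of the compounds shown alone.

In a functional assay on M21 cells (Homo sapiens) for antiproliferative activity, read by sulforhodamine B assay, with a stated time of 48 h (on this read-out higher numbers stand for weaker inhibition and lower numbers for stronger inhibition), compound 1 (`O=C1NCCN1c1ccc(S(=O)(=O)Nc2ccc(C3CCCCC3)cc2)cc1`) gives > 1000 nM, which is a limit of the assay and not a number. Among the compounds with values here, compound 2 (`O=C1NCCN1c1ccc(S(=O)(=O)Nc2ccccc2)cc1`) gives 200 nM, the only actual number available so far in this assay. Compound 3 (`O=C1NCCN1c1ccc(S(=O)(=O)Nc2ccc(Cl)cc2)cc1`) has not yet been measured. It differs from compound 2 in one place: chloro in place of hydrogen on an aromatic carbon. In words, this is chloro in place of hydrogen on an aromatic carbon.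

Within the data shown here, only one measured step bears on this change, the replacement of cyclohexyl by hydrogen on an aromatic carbon, which gave an at least 5.0-fold lower number from compound 1 to compound 2 (0.69 log units; beyond the scatter). Read in reverse, that step links a substituent on the ring with a higher number, so a rise is expected for compound 3 as well. Chloro brings a single heavy atom and no ring, so the rise is expected to be small. The estimated change is a 2.0-fold higher number from compound 2 to compound 3 (0.30 log units; within the scatter), close to the edge of the usual scatter. Compound 3 is expected at about 400 nM, with an estimated range of 120 nM to 1300 nM.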

Compound 3, half-maximal inhibitory concentration: 90 nM
The estimate for compound 3 lay 4.4-fold (0.65 log units) above the measured number, and the stated range ends above it.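

The result shows that a substituent at this position, on an aromatic carbon para to a large group, need not go with a higher number. Compound 1 had offered only cyclohexyl there, whereas in this assay the change from phenyl to 4-chlorophenyl gives a 2.2-fold lower number from compound 2 to compound 3 (0.35 log units; beyond the scatter), a modest step but one beyond the scatter. The same position also separates chloro from cyclohexyl clearly, with an at least 11-fold lower number from compound 1 to compound 3 (1.04 log units; beyond the scatter), and the value of compound 1 is a limit of the assay and not a number, so this step gives only a minimum size: the limit of > 1000 nM in this assay, at which 1 of the 3 values shown sits.

With only hydrogen, chloro and cyclohexyl at this position, the three compounds set no trend, and they leave open whether a fluoro, a methoxy, an amine or a carboxylic acid would follow chloro towards a lower number or cyclohexyl towards a higher one. Also open, as far as these compounds go, is where, between chloro and cyclohexyl, the number starts to rise, which a methyl group or a longer chain such as butyl could help to place, and whether the step from hydrogen to chloro holds in any cells other than those of this one assay.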